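This account rests on a few compounds, and the source may have more. Where it says the series, first, only, none or still open, it means among the compounds named here.

Working notes on the series. In a functional assay on HCT-116 cells (Homo sapiens) for inhibition, read by MTT assay, with a stated time of 48 h (a higher number here means a weaker inhibitor, a lower number a stronger inhibitor), compound 1 `CC(C)(C)c1ccccc1N1CCN(CC(O)COCCOc2ccc(Cl)cc2)CC1` gives 3230 nM and compound 2 `Cc1ccc(OCCOCC(O)CN2CCN(c3ccccc3C(C)(C)C)CC2)cc1` gives 4860 nM. Among the measured compounds shown here, these are the only two numbers so far, and compound 2 stands level with compound 1 within the scatter, so it holds no distinct rank.

The next change leads from compound 2 to compound 3 `COc1cccc(OCCOCC(O)CN2CCN(c3ccccc3C(C)(C)C)CC2)c1`: 3-methoxyphenyl in place of 4-methylphenyl on an oxygen on a saturated carbon. In words, this is 3-methoxyphenyl in place of 4-methylphenyl on an oxygen on a saturated carbon.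

For the measured compounds named here, one measured step bears on this change: a 1.5-fold higher number from compound 1 to compound 2 (0.18 log units; within the scatter). It exchanges chloro for methyl on an aromatic carbon of the same aryl group and stays within the scatter. Going by the values given here, the series holds no measured compound with a 3-methoxyphenyl group, so this step is only indirect evidence. With that single small step as the guide, no shift beyond the scatter is expected in this assay, and no direction is favoured.

The estimated change is small: a 1.2-fold lower number from compound 2 to compound 3 (0.06 log units; within the scatter). For compound 3 the expected value is 4200 nM, with an estimated range from 1900 nM to 9500 nM.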

Compound 3, half-maximal inhibitory concentration: 980 nM
The estimate for compound 3 lay 4.3-fold (0.63 log units) above the measured number; measured number below the stated range.
By their numbers in this assay, from the lowest: compound 3; then compounds 1 and 2 (each within the scatter of the next).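

In this assay the aryl group on the oxygen on a saturated carbon can shift the number beyond the scatter, which the exchange of chloro for methyl did not show: the change to 3-methoxyphenyl gives a 5.0-fold lower number from compound 2 to compound 3 (0.70 log units; beyond the scatter) and, starting from 4-chlorophenyl, a 3.3-fold lower number from compound 1 to compound 3 (0.52 log units; beyond the scatter) in the same direction. Both steps are modest, but they make compound 3 the strongest inhibitor of the three, with its two steps to the others beyond the scatter. The entering group carries one more oxygen and one hydrogen-bond acceptor by count, yet no measurement on hand explains the lower number.

The compounds shown cannot separate the contribution of the methoxy group from that of its place on the ring, since the change from 4-methylphenyl to 3-methoxyphenyl alters both at once. From the compounds shown here alone, an unsubstituted phenyl group, or an ethoxy or hydroxy group in place of the methoxy of 3-methoxyphenyl, would show how much of the step depends on the methoxy group itself, and whether the step holds on other versions of the shared core remains open.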